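Removing One Chloro Group: Effect on SW-620 Cytotoxicity

This account rests on a few compounds, and the source may have more. Where it says the series, first, only, none or still open, it means among the compounds named here.

Compound 1 `ClCc1ccccc1Cn1cnc2c(Cl)nc(Cl)nc21`: 150 nM
Compound 2 `ClCc1ccccc1Cn1cnc2c(Cl)ncnc21`: 1770 nM
Compound 3 `ClCc1ccc(Cn2cnc3nc(Cl)nc(Cl)c32)cc1`: 13200 nM

In a functional assay on SW-620 cells (Homo sapiens) for cytotoxicity, read by sulforhodamine B assay, with a stated time of 48 h (on this read-out lower numbers stand for stronger inhibition of growth and higher numbers for weaker inhibition of growth), compound 1 gives 150 nM, compound 2 gives 1770 nM, and compound 3 gives 13200 nM. Compound 1 and compound 3 hold the same atoms joined differently; the difference between the two cores is not broken down here. The change hydrogen in place of chloro on an aromatic carbon produced a 12-fold higher number from compound 1 to compound 2 (1.07 log units; beyond the scatter). Compound 4 `ClCc1ccc(Cn2cnc3ncnc(Cl)c32)cc1` has not yet been measured; it arises from compound 3 by the same change, (hydrogen in place of chloro on an aromatic carbon), at a place described in the same words. In this assay the expected step is a 7.6-fold higher number from compound 3 to compound 4 (0.88 log units; beyond the scatter), which rests on a 12-fold higher number from compound 1 to compound 2 (1.07 log units; beyond the scatter). Compound 4 is therefore estimated at 100000 nM, with a likely range from 25000 nM to 400000 nM, and a weak compound like this may be reported only as a limit.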

Compound 4, concentration for 50% growth inhibition: 2570 nM
For compound 4 the middle estimate is 39-fold (1.59 log units) above the measured one, and the stated range ends above it.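

Replacing the chloro group with hydrogen on an aromatic carbon gave, in this assay, a 5.1-fold lower number from compound 3 to compound 4 (0.71 log units; beyond the scatter) while the same change on the core of compound 1 went the other way: the same change on two cores in this assay, a 12-fold higher number (1.07 log units; beyond the scatter) from compound 1 to compound 2 and a 5.1-fold lower number (0.71 log units; beyond the scatter) from compound 3 to compound 4, 61-fold (1.78 log units) apart, beyond the scatter of two such steps

The step therefore did not carry from one core to the other in this series, either in direction or in size. These two pairs show that the outcome of this change differs between the two cores, but they do not show which difference between the cores is responsible or how the change would behave on any further core.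

The compounds shown leave open what an amine, a methoxy group or a fluoro group would do in place of the chloro group on either core. They also leave open whether such a group would give the same split between the two cores.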